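Swapping the Amide Aryl Group: Estimating Compound 4

The source may report more compounds than this note shows. Statements on the series, on what has been measured and on what is new or still open speak of the compounds shown alone.

Three compounds that share one core were tested in a functional assay on the whole organism for inhibition, with Rattus norvegicus as the target, read by cytopathic effect and paw edema, at a dose of 100 mg/kg by the oral route; a lower number here means less inhibition, a higher number more inhibition at the dose given (going by the name of the read-out):
compound 1 `CCCCNC(=O)c1c(O)c2cccnc2n(-c2ccccc2)c1=O` gives 20.4%;
compound 2 `O=C(Nc1ccccc1)c1c(O)c2cccnc2n(-c2ccccc2)c1=O` gives -15%;
compound 3 `O=C(Nc1ccncc1)c1c(O)c2cccnc2n(-c2ccccc2)c1=O` gives 24.3%.

Compound 3 holds the highest of the three numbers, though its gap to compound 1 lies within the scatter; only compound 2 stands clearly apart from it. Compound 4 `O=C(Nc1nccs1)c1c(O)c2cccnc2n(-c2ccccc2)c1=O` differs from compound 3 in one place: 1,3-thiazol-2-yl in place of pyridin-4-yl on an amide-type nitrogen. Within the data shown here, two measured steps bear on this change. The step of a number 39.3 percentage points higher from compound 2 to compound 3 (beyond the scatter) shows that the group on the amide-type nitrogen can matter greatly, while the step of a number 3.9 percentage points higher from compound 1 to compound 3 (within the scatter) shows that two quite different groups can give the same number. Among the measured compounds shown here, no measured compound carries a five-membered aromatic ring at this position, so the direction is uncertain. Compound 4 is expected to give 15%, between -15% and 40%, a change of a number 9.3 percentage points lower from compound 3 to compound 4 (within the scatter) that is estimated to stay within the scatter.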

Compound 4, a percentage reported as inhibition, in the whole organism at one dose (the size of the read-out at that dose, not a potency): 2.5%
Beside the measured number, compound 4's estimate is 12.5 percentage points above it; the range from low to high includes it.
By their numbers in this assay, from the lowest: compound 2; then compound 4; then compounds 1 and 3 (each within the scatter of the next).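

The step of a number 21.8 percentage points lower from compound 3 to compound 4 (beyond the scatter) and the step of a number 17.9 percentage points lower from compound 1 to compound 4 (beyond the scatter) set 1,3-thiazol-2-yl on the amide-type nitrogen apart from pyridin-4-yl and butyl, while the step of a number 17.5 percentage points higher from compound 2 to compound 4 (beyond the scatter) sets it apart from phenyl too. Two aromatic rings that each hold a ring nitrogen therefore do not give matching numbers, so having a ring nitrogen does not by itself fix the outcome at this position.

From the compounds shown here alone, whether a thiophen-2-yl ring, with sulfur but no ring nitrogen, or a 1,3-oxazol-2-yl ring would land nearer compound 2 or compound 3 stays open. Nothing shown explains these steps.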